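The compounds below may be only part of what the source reports. "The series", "measured", "known", "first", "only" and "open" are said of these compounds alone.

Measured so far in a functional assay on U-87MG ATCC cells (Homo sapiens) for antiproliferative activity, read by MTT assay, with a stated time of 48 h; a higher number here means a weaker inhibitor, a lower number a stronger inhibitor:

- compound 1 `O=C(/C=C\Nc1ccc(Cl)cc1)c1cn(-c2ccccc2)nc1-c1ccc(F)cc1`: in this assay compound 1 gives 8900 nM
- compound 2 `COc1ccc(N/C=C\C(=O)c2cn(-c3ccccc3)nc2-c2ccc(OC)cc2)cc1`: in this assay compound 2 gives > 50000 nM, which is a limit of the assay and not a number
- compound 3 `COc1cc(-c2nn(-c3ccccc3)cc2C(=O)/C=C\Nc2ccc(Cl)cc2)cc(OC)c1OC`: in this assay compound 3 gives 3210 nM

Of the two numbers in this assay, compound 3 has the lower one; compound 1 sits higher by a margin beyond the usual scatter, and compound 2 contributes only a limit (the limit of > 50000 nM in this assay, at which 1 of the 3 values shown sits).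

The step to compound 4 `COc1cc(-c2nn(-c3ccccc3)cc2C(=O)/C=C\Nc2ccc(O)cc2)cc(OC)c1OC` is hydroxy in place of chloro on an aromatic carbon. Among the compounds with values here, no pair of measured compounds differs in this one place, so the size of the step has no measured precedent in this assay. The expectation is a shift toward a higher number in this assay for compound 4, of modest size, though a result within the scatter of compound 3 would not be surprising.

Compound 4 is estimated at 6000 nM, with a range of 1500 nM to 25000 nM, corresponding to an expected step of a 1.9-fold higher number from compound 3 to compound 4 (0.27 log units; within the scatter).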

Compound 4, half-maximal inhibitory concentration: 1800 nM
Compound 4: middle estimate off by 3.3-fold (0.52 log units), on the high side, within the range that was stated.
By their numbers in this assay, from the lowest: compounds 4 and 3 (each within the scatter of the next); then compound 1. At a limit, above all of these: compound 2.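

In this assay, hydroxy in place of chloro on an aromatic carbon, para to a large group, gives a 1.8-fold lower number from compound 3 to compound 4 (0.25 log units; within the scatter), so this exchange does not separate compound 3 from compound 4. The earlier compounds shown here offered no pair differing in this one place, and this step now shows that a group with a hydrogen-bond donor and acceptor can stand where chloro has neither, without a shift beyond the scatter. No measured property in hand bears on this result.

A single step cannot show whether other groups at this carbon, such as an amine or a carboxylic acid, would also stay within the scatter of compound 3. From the compounds shown here alone, whether the same exchange would read alike on the core of compound 1 also remains open.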